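The compounds below may be only part of what the source reports. "The series", "measured", "known", "first", "only" and "open" are said of these compounds alone.

Measured compounds:
- compound 1 `CN1CCC(C(=O)N2Cc3c(NC(=O)C4CC4)n[nH]c3C2(C)C)CC1`, 1420 nM in a functional assay on A2780 cells (Homo sapiens) for antiproliferative activity, read by fluorescence, with a stated time of 72 h; a lower number here means a stronger inhibitor, a higher number a weaker inhibitor
- compound 2 `CN1CCC(C(=O)Nc2n[nH]c3c2CN(C(=O)C(C)(C)C)C3(C)C)CC1`, 350 nM in this assay

Of the compounds shown here, two have been measured in this assay. Compound 1 gives 1420 nM, which is the higher of the two numbers. Compound 2 gives 350 nM, a lower number that lies beyond the usual scatter of the assay, so compound 1 is the weaker of the two on what has been measured. Among the compounds with values here, the two compounds differ in more than one place, so no single step connects them and no part of that gap can be traced to one change.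

Compound 3 `CCCNC(=O)Nc1n[nH]c2c1CN(C(=O)C1CCN(C)CC1)C2(C)C` has not yet been measured. It differs from compound 1 in one place:

propylamino in place of cyclopropyl on a carbonyl carbon

That is, propylamino in place of cyclopropyl on a carbonyl carbon, turning (cyclopropylcarbonyl)amino into (propylcarbamoyl)amino. Within the data shown here, no measured pair shows this change, so the expected direction is uncertain. Compound 3 is estimated to give 1100 nM, within a range of 300 nM to 4000 nM. The step from compound 1 to compound 3 is expected to be a 1.3-fold lower number from compound 1 to compound 3 (0.11 log units; within the scatter), which is within the scatter.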

Compound 3, half-maximal inhibitory concentration: 650 nM
For compound 3 the middle estimate is 1.7-fold (0.23 log units) above the measured one, and the stated range covers the measured number.
By their numbers in this assay, from the lowest: compounds 2 and 3 (each within the scatter of the next); then compound 1.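

In this assay, within the data shown here, putting propylamino in place of cyclopropyl on a carbonyl carbon, which turns (cyclopropylcarbonyl)amino into (propylcarbamoyl)amino, gives a 2.2-fold lower number from compound 1 to compound 3 (0.34 log units; beyond the scatter); this step is modest but beyond the scatter, and it is the first difference in this set that can be traced to one place, showing that the number responds to what sits at this position. Among these compounds, the single step changes several things at once: a three-membered ring of carbon only leaves, and an open chain with a nitrogen and one hydrogen-bond donor enters, so the step belongs to the whole swap and not to any one of these features. Nothing measured on these compounds offers an explanation for the step.

Going by these compounds, it remains open whether cyclopropylamino, which would keep the ring and bring in the nitrogen, or butyl, a longer chain without that nitrogen, would move the number in the same direction. Among the compounds shown here, with only one step at this position, it is also open how the number would respond to a longer chain on the nitrogen, such as butylamino.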